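From methoxy to trifluoromethyl: compound 3 to compound 4

A few compounds are considered here, and "the series" means these few. Any claim that something is new, unique, unknown or untested is made for them only; others in the source may bear on it.

In an ADME assay on HaCaT cells (Homo sapiens) for cytotoxicity, read by MTT assay, with a stated time of 48 h (a lower number here means a stronger inhibitor, a higher number a weaker inhibitor), compound 3 `COc1ccc(-c2nn(-c3ccccc3)cc2-c2nc3cc(OC)ccc3[nH]2)cc1` gives only a limit, > 50000 nM. Compound 2 `COc1ccc(-c2nn(-c3ccccc3)cc2-c2nc3cc(Br)ccc3[nH]2)cc1` also gives only a limit, > 50000 nM. Compound 1 `FC(F)(F)c1ccc2[nH]c(-c3cn(-c4ccccc4)nc3-c3ccc(Cl)cc3)nc2c1` gives a true number, 41800 nM.

Compound 4 `COc1ccc(-c2nn(-c3ccccc3)cc2-c2nc3cc(C(F)(F)F)ccc3[nH]2)cc1` differs from compound 3 by one change: trifluoromethyl in place of methoxy on an aromatic carbon. Among the compounds with values here, the only measured step, a step that the two limits leave unreadable from compound 2 to compound 3, offers no size to carry over. The best guide is compound 1, which also carries trifluoromethyl but differs elsewhere and gives 41800 nM. A modest move toward stronger inhibition in this assay is therefore expected, though a limit remains quite possible. The expected change is an at least 1.1-fold lower number from compound 3 to compound 4 (0.04 log units; that floor lies within the scatter), an uncertain estimate. For compound 4 the estimated value is 45000 nM, with an expected range from 25000 nM to 75000 nM.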

Compound 4, half-maximal inhibitory concentration: > 50000 nM
Compound 4: only a limit was reported; the forecaster's own chance of this, stated with the estimate: 50%; middle value at least 1.1-fold (0.04 log units) away from the limit.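

In this assay, trifluoromethyl at this position leaves compound 4 with only a limit, as bromo left compound 2 and methoxy left compound 3, so the steps among these three cannot be read: the limit of > 50000 nM in this assay, at which 3 of the 4 values shown sit.

With trifluoromethyl kept, methoxy in place of chloro gives an at least 1.1-fold higher number from compound 1 to compound 4 (0.07 log units; that floor lies within the scatter). Trifluoromethyl alone therefore does not bring a true number, which among these compounds appears only in compound 1, the one carrying chloro.

Going by these compounds, how far compound 2, compound 3 and compound 4 lie past the limit stays open. So does whether an amine or a carboxylic acid at this position would give a true number in this assay.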